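Iodo to hydrogen: what compound 4 should give

The source may hold more compounds than are shown below. What is called first, only, known or untested is meant among the compounds shown, and "the series" means these compounds.

Three compounds built on closely related cores were tested in a functional assay on PC-3 cells (Homo sapiens) for antiproliferative activity, read by MTT assay; on this read-out higher numbers stand for weaker inhibition and lower numbers for stronger inhibition. Compound 1 `COc1cc(-c2nnc(Sc3ncnc4ccccc34)s2)cc(OC)c1OC` gives 19000 nM. Compound 3 `COc1cc(-c2nnc(Sc3ncnc4ccc(I)cc34)s2)cc(OC)c1OC` gives 12200 nM, and the move to compound 1 is hydrogen in place of iodo on an aromatic carbon, with a 1.6-fold higher number from compound 3 to compound 1 (0.19 log units; within the scatter). Compound 2 `COc1cc(-c2nnc(Sc3ncnc4ccc(I)cc34)o2)cc(OC)c1OC` gives 8900 nM; how its core differs from that of compound 3 is not broken down here. Compound 4 `COc1cc(-c2nnc(Sc3ncnc4ccccc34)o2)cc(OC)c1OC` has not yet been measured in this assay. Its change from compound 2 is hydrogen in place of iodo on an aromatic carbon, the same kind of change as that from compound 3 to compound 1, and the surroundings of the place are described in the same words. Resting on a 1.6-fold higher number from compound 3 to compound 1 (0.19 log units; within the scatter), compound 4 is expected to give about 14000 nM, a step of a 1.6-fold higher number from compound 2 to compound 4 (0.20 log units; within the scatter). The estimate for compound 4 is expected to fall between 7000 nM and 30000 nM.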

Compound 4, half-maximal inhibitory concentration: 5600 nM
Compound 4: middle estimate off by 2.5-fold (0.40 log units), on the high side; measured number below the stated range.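

In this assay, hydrogen in place of iodo on an aromatic carbon gives a 1.6-fold lower number from compound 2 to compound 4 (0.20 log units; within the scatter). Set beside the earlier step, the two cores cannot be told apart: the same change on two cores in this assay, a 1.6-fold higher number (0.19 log units; within the scatter) from compound 3 to compound 1 and a 1.6-fold lower number (0.20 log units; within the scatter) from compound 2 to compound 4, 2.5-fold (0.39 log units) apart, within the scatter of two such steps. This shows that neither step stands clear of the scatter and that the change can be carried between these two cores without a resolved difference, but it does not show that the cores truly respond alike, and two pairs say nothing about other cores in the series.

The compounds shown leave open whether a different group at that place, such as an amine or a carboxylic acid, would give a step beyond the scatter.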